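From Methyl to Nitro: What Compound 3 Might Show

The source may hold more compounds than are shown below. What is called first, only, known or untested is meant among the compounds shown, and "the series" means these compounds.

Of the compounds shown here, two that share a core have so far been measured in a functional assay on the whole organism (integument) for inhibition, with Chilo suppressalis as the target, read by scintillation counting, with a stated time of 72 h; a higher number here means a weaker inhibitor, a lower number a stronger inhibitor. Compound 1 `O=C(Nc1nnc(-c2ccc(Cl)cc2)s1)c1ccccc1` reaches only a limit of the assay, > 5010 nM, and that is the limit of > 5010 nM in this assay, at which 1 of the 2 values shown sits. Within the data shown here, compound 2 `COc1cccc(OC)c1C(=O)Nc1nnc(-c2ccc(C)cc2)s1` gives 1230 nM in this assay, the only actual number recorded, so it stands alone as the reference point for anything that follows. Compound 3 `COc1cccc(OC)c1C(=O)Nc1nnc(-c2ccc([N+](=O)[O-])cc2)s1` differs from compound 2 in a single place: nitro in place of methyl on an aromatic carbon, para to a large group. Among the measured compounds shown here, no measured step between two compounds covers a change of this kind, so neither its size nor its direction in this assay can be read from what is known. The step from compound 2 to compound 3 is expected to be a 1.2-fold higher number from compound 2 to compound 3 (0.09 log units; within the scatter), possibly no more than the usual scatter. Compound 3 is therefore expected to give 1500 nM in this assay, within a range from 400 nM to 6000 nM.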

Compound 3, half-maximal inhibitory concentration: 355 nM
Compound 3: middle estimate off by 4.2-fold (0.63 log units), on the high side; measured number below the stated range.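

In this assay, among these compounds, the change from 4-methylphenyl to 4-nitrophenyl gives a 3.5-fold lower number from compound 2 to compound 3 (0.54 log units; beyond the scatter), the only step here that can be read between two measured compounds. This shows that the position para to a large group is not indifferent to what sits on it: nitro, with 3 heavy atoms and 2 hydrogen-bond acceptors, replaces methyl, with 1 heavy atom and none, and the number moves beyond the scatter, something compound 1 and compound 2 alone, which differ in more than one place, could not show. Nothing measured here bears on the cause of this step.

As far as these compounds go, whether an amine, a nitrile or a carboxylic acid in the same place would move the number in the same direction stays open. So does whether nitro would give a similar step on the unsubstituted benzamide side of compound 1.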